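Swapping an aryl amide for a benzyl amide

A few compounds are considered here, and "the series" means these few. Any claim that something is new, unique, unknown or untested is made for them only; others in the source may bear on it.

Three compounds share one core and differ only in the group on an amide-type nitrogen. In an ADME assay on HCT-116 cells (Homo sapiens) for cytotoxicity, read by MTT assay, with a stated time of 72 h (a lower number here means a stronger inhibitor, a higher number a weaker inhibitor), compound 1 `COc1ccc(NC(=O)c2cccc(/C=C3\CC(=O)N(c4ccccc4)C3=O)c2)cc1` reaches only the limit > 100000 nM. Compound 2 `CCc1cccc(NC(=O)c2cccc(/C=C3\CC(=O)N(c4ccccc4)C3=O)c2)c1` gives 81200 nM in this assay. Compound 3 `Cc1cccc(NC(=O)c2cccc(/C=C3\CC(=O)N(c4ccccc4)C3=O)c2)c1` likewise reaches only the limit > 100000 nM. The measured steps are small: an at least 1.2-fold lower number from compound 1 to compound 2 (0.09 log units; that floor lies within the scatter), an at least 1.2-fold higher number from compound 2 to compound 3 (0.09 log units; that floor lies within the scatter), and a step that the two limits leave unreadable from compound 1 to compound 3; with the limit of > 100000 nM in this assay, at which 2 of the 3 values shown sit, the numbers are hardly separable. Compound 4 `O=C(NCc1ccccc1)c1cccc(/C=C2\CC(=O)N(c3ccccc3)C2=O)c1` carries benzyl in place of 3-methylphenyl on an amide-type nitrogen. Within the data shown here, no measured step exchanges an aromatic group for a benzyl group, so there is no guide to the size or direction of this change, and nothing beyond the scatter is expected. The step of a number no higher from compound 3 to compound 4 (the limit leaves the size open) is therefore expected to be flat. Compound 4 is estimated at 100000 nM, between 40000 nM and 250000 nM.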

Compound 4, half-maximal inhibitory concentration: > 100000 nM
Compound 4: no number, only a limit; the forecaster's own chance of this, stated with the estimate: 65%; the middle value sits exactly at the limit.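

In this assay compound 4 gives > 100000 nM, which is a limit of the assay and not a number. Set against the one real value in the series, the change is an at least 1.2-fold higher number from compound 2 to compound 4 (0.09 log units; that floor lies within the scatter), while the steps from compound 1 and compound 3 cannot be read. Benzyl on this amide-type nitrogen therefore gives no readable gain over the aromatic groups, and the compounds remain hard to separate: the limit of > 100000 nM in this assay, at which 3 of the 4 values shown sit.

Going by these compounds, what a longer chain such as phenethyl, or a benzyl group carrying an amine, would do on this nitrogen stays open. Also open, on these data alone, is whether any group here can bring the number clearly under the limit.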